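The compounds below may be only part of what the source reports. "The series", "measured", "known", "first", "only" and "open" are said of these compounds alone.

Of the compounds shown here, three that share one core have been tested in an assay on HEK-293T cells for displacement of a labelled ligand from corticotropin-releasing factor receptor 1 (Homo sapiens), read by scintillation counting, with a stated time of 2 h; on this read-out lower numbers stand for stronger inhibition and higher numbers for weaker inhibition. Compound 1 `CCCCN(CC)c1cc(C)nc2c1NC(=O)CN2c1ccc(C)cc1C` gives 3.9 nM in this assay, the lowest of the three numbers. Compound 2 `CCN(C)c1cc(C)nc2c1NC(=O)CN2c1ccc(C(C)C)cc1Br` gives 16.4 nM, and compound 3 `Cc1cc(N(C)C)c2c(n1)N(c1ccc(C(C)C)cc1Br)CC(=O)N2CCCCF` gives 21.6 nM; both of these stand beyond the usual scatter from compound 1, so compound 1 shows the strongest binding of the three. Compound 2 and compound 3 each differ from compound 1 in more than one place, so their gaps cannot be tied to any single change.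

Compound 4 `CCCCN(CC)c1cc(C)nc2c1NC(=O)CN2c1ccc(Br)cc1CC` has not yet been measured. It differs from compound 1 in one place: 4-bromo-2-ethylphenyl in place of 2,4-dimethylphenyl on a nitrogen on an aromatic ring in a ring. For the measured compounds named here, no measured pair isolates this kind of swap, so there is no direct precedent for its size. The two compounds carrying bromine on that ring, compound 2 and compound 3, give the higher numbers, yet each also differs elsewhere, so only a modest weakening, close to the scatter, is expected. The step from compound 1 to compound 4 is estimated at a 1.7-fold higher number from compound 1 to compound 4 (0.22 log units; within the scatter). Compound 4 is therefore expected to give 6.5 nM, with a range from 2.5 nM to 18 nM.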

Compound 4, inhibition constant: 2.5 nM
Beside the measured number, compound 4's estimate is 2.6-fold (0.41 log units) above it; the range from low to high includes it.
By their numbers in this assay, from the lowest: compounds 4 and 1 (each within the scatter of the next); then compounds 2 and 3 (each within the scatter of the next).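

In this assay, putting 4-bromo-2-ethylphenyl in place of 2,4-dimethylphenyl gives a 1.6-fold lower number from compound 1 to compound 4 (0.19 log units; within the scatter) and so leaves the two compounds level. This position on the shared core therefore tolerates a swap to a group of 9 heavy atoms from one of 8, with no measurable loss of binding. Compound 4 also carries bromine on this ring and still binds as well as compound 1, so bromine there does not by itself go with a higher number. No measurement shown here offers an explanation for this result.

Going by these compounds, the bromine and the ethyl group enter together in this one step, so what each contributes alone remains open. On these data alone, it also remains open how a methoxy group or a chlorine on this ring would compare.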